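A few compounds are considered here, and "the series" means these few. Any claim that something is new, unique, unknown or untested is made for them only; others in the source may bear on it.

Working notes on the series. In a functional assay on KARPAS-422 cells (Homo sapiens) for antiproliferative activity, read by resazurin assay, with a stated time of 72 h (on this read-out higher numbers stand for weaker inhibition and lower numbers for stronger inhibition), compound 1 `Cc1cc(C)c(CN2CCc3c(Cl)cc([C@H](CO)[C@H]4CCOC4)c(Cl)c3C2=O)c(=O)[nH]1` gives 15 nM, the lower of the two single numbers available. The nearest, compound 3 `COc1cc(C)[nH]c(=O)c1CN1CCc2c(Cl)cc([C@@H](O)C3COC3)c(Cl)c2C1=O` at 10600 nM, lies far higher, beyond the scatter. Compound 2 `COC(c1cc(Cl)c2c(c1Cl)C(=O)N(Cc1c(C)cc(C)[nH]c1=O)CC2)C1CCN(C(=O)CO)CC1` has no single number, and its entries read 3140 nM; 21 nM (2 entries).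

Compound 4 `Cc1cc(C)c(CN2CCc3c(Cl)cc([C@@H](CO)[C@H]4CCCO4)c(Cl)c3C2=O)c(=O)[nH]1` has the same atoms as compound 1, joined differently: a group of 8 heavy atoms (6 carbon, 2 oxygen; one five-membered non-aromatic ring with 1 hetero atom) in place of a group of 8 heavy atoms (6 carbon, 2 oxygen; one five-membered non-aromatic ring with 1 hetero atom), on an aromatic carbon. The change sits on an aromatic carbon, ortho to a chloro group, and the rest of the core of compound 1 is kept.

Going by the values given here, no measured step in this assay isolates this kind of change, so the expectation rests on compound 1 at 15 nM. A moderate rise in the number is expected, with the estimated move being a 3.0-fold higher number from compound 1 to compound 4 (0.48 log units; beyond the scatter). The range is kept wide because of the several entries of compound 2 in this assay, 3140 nM; 21 nM (2 entries). For compound 4 the estimated value is 45 nM, with an expected range from 8 nM to 400 nM.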

Compound 4, half-maximal inhibitory concentration: 535 nM
Beside the measured number, compound 4's estimate is 12-fold (1.08 log units) below it; measured number outside the range, above it.
By their numbers in this assay, from the lowest: compound 1; then compound 4; then compound 3.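

In this assay, rejoining the same atoms on this aromatic carbon, ortho to a chloro group, gives a 36-fold higher number from compound 1 to compound 4 (1.55 log units; beyond the scatter) and so counts as a large step. Both groups have 8 heavy atoms (6 carbon, 2 oxygen), one five-membered non-aromatic ring with 1 hetero atom, 1 hydrogen-bond donor, 2 hydrogen-bond acceptors and 2 defined stereocentres, so at this place the number depends on how the atoms are joined and not only on which atoms are present. The earlier compounds shown here offered no pair that differs in one place, so this sensitivity could not be read from them.

Which part of the rearrangement carries the step stays open, as does how a primary amine or a carboxylic acid in place of the hydroxyl would read here. Nothing in the data at hand accounts for the size of the step.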